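Pyrazole chain end: from methylamino link to carbamoyl

The compounds below may be only part of what the source reports. "The series", "measured", "known", "first", "only" and "open" are said of these compounds alone.

Two chain-end variants on the shared core have been measured in a functional assay on HBC4 cells (Homo sapiens) for inhibition, read by sulforhodamine B assay, with a stated time of 48 h; on this read-out higher numbers stand for weaker inhibition of growth and lower numbers for stronger inhibition of growth. Within the data shown here, compound 1 `CCCCCCCCCCCC[C@@H](O)[C@H]1CC[C@H]([C@H](O)CCCCCCCCCCN(C)C(=O)c2ccnn2C)O1` gives 10000 nM, and compound 2 `CCCCCCCCCCCC[C@@H](O)[C@H]1CC[C@H]([C@H](O)CCCCCCCCCCNCc2ccnn2C)O1` gives 1820 nM, the lower of the two numbers so far. Among the measured compounds shown here, the only measured step is a 5.5-fold lower number from compound 1 to compound 2 (0.74 log units; beyond the scatter).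

Compound 3 `CCCCCCCCCCCC[C@@H](O)[C@H]1CC[C@H]([C@H](O)CCCCCCCCCCC(=O)Nc2ccnn2C)O1` is the next variant, and the change from compound 2 is (1-methyl-1H-pyrazol-5-yl)carbamoyl in place of ((1-methyl-1H-pyrazol-5-yl)methyl)amino on a saturated chain carbon, ten or more bonds along the chain from an oxygen on a saturated carbon and a saturated ring carbon. For the measured compounds named here, no measured compound carries the (1-methyl-1H-pyrazol-5-yl)carbamoyl group, so the evidence is thin and rests on a single pair. The new group does bring back a carbonyl, which compound 2 lacks. Compound 1 also carries a carbonyl, in a differently built group, and gives 10000 nM. On that one comparison, part of the gain in a 5.5-fold lower number from compound 1 to compound 2 (0.74 log units; beyond the scatter) is expected to be lost, without the number necessarily returning all the way to that of compound 1. The expected change is a 2.5-fold higher number from compound 2 to compound 3 (0.39 log units; beyond the scatter), toward a higher number and weaker inhibition of growth. For compound 3 the estimated value is 4500 nM, with an expected range of 1700 nM to 10000 nM.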

Compound 3, concentration for 50% growth inhibition: 100000 nM
Estimate against measurement, compound 3: 22-fold (1.35 log units) below; measured number outside the range, above it.
By their numbers in this assay, from the lowest: compound 2; then compound 1; then compound 3.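

In this assay, this chain-end position proves far more sensitive to the way the pyrazole is linked than the first pair suggested: a 55-fold higher number from compound 2 to compound 3 (1.74 log units; beyond the scatter), a larger step than a 5.5-fold lower number from compound 1 to compound 2 (0.74 log units; beyond the scatter). Carrying a carbonyl does not fix the level of growth inhibition, since compound 1 and compound 3 both have one and still a 10-fold higher number from compound 1 to compound 3 (1.00 log units; beyond the scatter), so among these three compounds the arrangement of the link counts as well as the presence of the carbonyl, and compound 2, the only one without a carbonyl, gives the lowest number. Nothing measured here accounts for these differences between the chain ends.

Still open, on these data alone, is whether the lower number of compound 2 comes from the amine link alone or needs the 1-methylpyrazole, which a simple dimethylamino chain end or a benzylamino group on the same chain would separate. Also open, as far as these compounds go, is how the carbamoyl link of compound 3 would read with a methyl group in place of the amide hydrogen, or with a longer chain of methylene groups leading to the pyrazole.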